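A thiophene sulfonamide tested for cytotoxicity

A few compounds are considered here, and "the series" means these few. Any claim that something is new, unique, unknown or untested is made for them only; others in the source may bear on it.

Compound 3 `COc1ccc([C@H]2CC(=O)N(c3cccc(NS(=O)(=O)c4cccc(Cl)c4C)c3)C2)cc1OC1CCCC1` carries a (3-chloro-2-methylphenyl)sulfonyl group on the nitrogen on an aromatic ring of the shared core. In a functional assay on HEK293 cells (Homo sapiens) for cytotoxicity (a lower number here means that less compound is tolerated, a higher number that more compound is tolerated), compound 3 gives only a limit, > 10000 nM. Compound 1 `CCCCNc1cccc(N2C[C@@H](c3ccc(OC)c(OC4CCCC4)c3)CC2=O)c1`, with butyl in that place, likewise reaches only a limit in this assay, > 10000 nM. Compound 2 `COc1ccc([C@H]2CC(=O)N(c3cccc(NS(=O)(=O)c4cccc(OC(F)(F)F)c4)c3)C2)cc1OC1CCCC1`, with 3-(trifluoromethoxy)phenyl on the sulfonyl sulfur, also stops at a limit in this assay, > 10000 nM. The step that the two limits leave unreadable from compound 1 to compound 3 and the step that the two limits leave unreadable from compound 2 to compound 3 therefore cannot be sized; what the three values share is the limit of > 10000 nM in this assay, at which 3 of the 3 values shown sit. Compound 4 `COc1ccc([C@H]2CC(=O)N(c3cccc(NS(=O)(=O)c4cc(Br)c(Cl)s4)c3)C2)cc1OC1CCCC1` differs from compound 3 in one place: 4-bromo-5-chlorothiophen-2-yl in place of 3-chloro-2-methylphenyl on a sulfonyl sulfur. The two measured steps onto compound 3 bear on this change only in that neither shows any value away from the limit because of the limit of > 10000 nM in this assay, at which 3 of the 3 values shown sit. Compound 4 is expected to behave the same way, with a step that the limit leaves unreadable from compound 3 to compound 4 that is estimated to stay within the scatter. The value of compound 4 in this assay is estimated at 15000 nM, with a range from 7000 nM to 40000 nM.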

Compound 4, half-maximal cytotoxic concentration: > 10000 nM
Compound 4: only a limit was reported; the forecaster's own chance of this, stated with the estimate: 85%; the middle value does not contradict the limit.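

In this assay compound 4 gives only a limit, > 10000 nM. The steps to compound 4 from compound 1, compound 2 and compound 3 therefore cannot be read: the limit of > 10000 nM in this assay, at which 4 of the 4 values shown sit. The compounds shown leave open at what concentration any of them would reach its half-maximal cytotoxic effect.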